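The source may hold more compounds than are shown below. What is called first, only, known or untested is meant among the compounds shown, and "the series" means these compounds.

Compound 1 `O=C(COc1ccccc1)Nc1nc(-c2ccccc2)n[nH]1` gives 2300 nM in an assay on CHO cells for displacement of a labelled ligand from adenosine receptor A3 (Homo sapiens), read by scintillation counting, with a stated time of 60 min; a lower number here means a stronger inhibitor, a higher number a weaker inhibitor. Compound 2 `O=C(COCc1ccccc1)Nc1nc(-c2ccccc2)n[nH]1` gives 4600 nM in this assay. Among the compounds with values here, the only step with a single change is a 2.0-fold higher number from compound 1 to compound 2 (0.30 log units; within the scatter), which touches the ether end of the molecule and not the aryl group on the shared core. On these two numbers compound 1 stands lowest, but its distance to compound 2 is within the scatter, so no order between them is claimed.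

Compound 3 `Cc1ccc(-c2n[nH]c(NC(=O)COc3ccccc3)n2)cc1` has not yet been measured in this assay. Against compound 1 the change is methyl in place of hydrogen on an aromatic carbon. Within the data shown here, no measured step bears on this change: the single step known concerns benzyl in place of phenyl on an oxygen on a saturated carbon, and that step itself stayed within the scatter. A small substituent added on the aromatic ring attached to the core gives no reason, from what has been measured, to expect a step beyond the scatter in either direction. Compound 3 is therefore expected near the value of compound 1, as no change at the digits printed from compound 1 to compound 3 (within the scatter). The estimate for compound 3 is 2300 nM, with a range from 800 nM to 6500 nM.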

Compound 3, inhibition constant: 3200 nM
Beside the measured number, compound 3's estimate is 1.4-fold (0.14 log units) below it; low and high end bracket the measured number.
By their numbers in this assay, from the lowest: compounds 1, 3 and 2 (each within the scatter of the next).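

The aryl end of the molecule, untouched by the earlier pair, now has its first single-change reading in this assay: 4-methylphenyl in place of phenyl gives a 1.4-fold higher number from compound 1 to compound 3 (0.14 log units; within the scatter) and so stays close to the parent. Within the data shown here, a methyl on an aromatic carbon, para to a large group, is therefore accepted here without a step beyond the scatter, and the single changes read so far, one at the ether end and one on the aryl group, both leave the number within the scatter of compound 1. No measurement on hand explains this result, and the size of the step does not allow any effect of the methyl to be told apart from the scatter.

Open, as far as these compounds go, is whether a different group at this same carbon, such as an amine, a carboxylic acid or a longer chain like propyl, would move the number beyond the scatter, and whether methyl elsewhere on this ring would read as it does here. Also open, from the compounds shown here alone, is how the core itself contributes, since all three compounds share it unchanged.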